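A few compounds are considered here, and "the series" means these few. Any claim that something is new, unique, unknown or untested is made for them only; others in the source may bear on it.

Compound 3 `CONC(=S)N/N=C1\C(=O)N(CN2CCN(c3ccc(OC)cc3)CC2)c2ccc(C)cc21` is one of three closely related compounds measured in an ADME assay on MT4 cells (Homo sapiens) for cytotoxicity, read by spectrophotometry, with a stated time of 5 days; a higher number here means that more compound is tolerated, a lower number that less compound is tolerated. In this assay compound 3 gives 324000 nM. Compound 2 `CONC(=S)N/N=C1\C(=O)N(CN2CCN(c3ccc(Cl)cc3)CC2)c2ccc(C)cc21` gives 300000 nM, and compound 1 `CONC(=S)N/N=C1\C(=O)N(CN2CCN(c3ccccc3)CC2)c2ccc(Cl)cc21` gives 267000 nM. All three numbers lie within the usual scatter of one another, so compound 3 is not set apart from either of its neighbours.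

Compound 4 `CONC(=S)N/N=C1\C(=O)N(CN2CCN(c3ccccc3)CC2)c2ccc(C)cc21` has not yet been measured. It differs from compound 3 in one place: hydrogen in place of methoxy on an aromatic carbon. Within the data shown here, the only measured step at that same aromatic carbon is the one from compound 2 to compound 3, where a methoxy took the place of a chloro, and it gave a 1.1-fold higher number from compound 2 to compound 3 (0.03 log units; within the scatter). Compound 1, which carries a hydrogen at that carbon but also differs from compound 3 elsewhere, gives a number within the scatter of compound 3 as well. Among the measured compounds shown here, nothing among the measured compounds points to this site mattering for how much compound is tolerated.

Compound 4 is therefore expected to give 300000 nM, with a range from 150000 nM to 600000 nM. The step this implies, a 1.1-fold lower number from compound 3 to compound 4 (0.03 log units; within the scatter), is expected to stay within the scatter.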

Compound 4, half-maximal cytotoxic concentration: 276000 nM
Beside the measured number, compound 4's estimate is 1.1-fold (0.04 log units) above it; the range from low to high includes it.
By their numbers in this assay, from the lowest: compounds 1, 4, 2 and 3 (each within the scatter of the next).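

Replacing the methoxy with hydrogen gives a 1.2-fold lower number from compound 3 to compound 4 (0.07 log units; within the scatter) in this assay, and hydrogen in place of chloro gives a 1.1-fold lower number from compound 2 to compound 4 (0.04 log units; within the scatter), so at this aromatic carbon, para to a large group, hydrogen, chloro and methoxy cannot be told apart on this read-out. Compound 4 also opens a one-place comparison at a second site on the core, where exchanging the chloro for a methyl gives a 1.0-fold higher number from compound 1 to compound 4 (0.01 log units; within the scatter), so neither site shows any measurable effect on how much compound is tolerated. No measured evidence is at hand on why these numbers stay so close together.

The compounds shown carry only hydrogen, chloro and methoxy at the first site and only chloro and methyl at the second, so what an amine, a carboxylic acid or a longer chain would do at either place stays open. Also open, going by these compounds, is whether a change at one site would read the same with a different group at the other.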